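A few compounds are considered here, and "the series" means these few. Any claim that something is new, unique, unknown or untested is made for them only; others in the source may bear on it.

Measured compounds and their results in a functional assay on Chem-3 cells for antagonist activity at metabotropic glutamate receptor 1 (Homo sapiens), read by fluorescence and calcium flux; on this read-out higher numbers stand for weaker inhibition and lower numbers for stronger inhibition:
- compound 1 `Cc1cc(C(=O)N2CCc3c(sc(NC(=O)c4ccc(F)cc4)c3C#N)C2)[nH]n1`: "not determined" (no result reported)
- compound 2 `COc1ccc(C(=O)Nc2sc3c(c2C#N)CCN(C(=O)c2cc(C)n[nH]2)C3)cc1`: "not determined" (no result reported)
- compound 3 `CC(C)c1cc(C(=O)N2CCc3c(sc(NCc4ccccc4)c3C#N)C2)[nH]n1`: 43200 nM

Within the data shown here, three compounds share a core, but only one carries a number. Compound 1 and compound 2 have no result in this assay, so nothing can be said about how they compare. Compound 3 gives 43200 nM in this assay, a high concentration, meaning that compound 3 is a weak inhibitor on this read-out. It is the only number shown, so there is no step between measured compounds to learn from.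

Compound 4 `Cc1cc(C(=O)N2CCc3c(sc(NCc4ccccc4)c3C#N)C2)[nH]n1` differs from compound 3 in a single place: methyl in place of isopropyl on an aromatic carbon. In words, a methyl replaces an isopropyl on an aromatic carbon of the five-membered aromatic ring that carries two nitrogen atoms.

Among the measured compounds shown here, since no measured pair shows what such a change does here, the expected step from compound 3 to compound 4 is a 1.2-fold higher number from compound 3 to compound 4 (0.06 log units; within the scatter), which is no change beyond the usual scatter. For compound 4 the estimate in this assay is 50000 nM, with a range from 15000 nM to 160000 nM.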

Compound 4, half-maximal inhibitory concentration: 1420 nM
Beside the measured number, compound 4's estimate is 35-fold (1.55 log units) above it; measured number below the stated range.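

In this assay the group on this aromatic carbon of the five-membered aromatic ring turns out to matter a great deal: replacing isopropyl with methyl gives a 30-fold lower number from compound 3 to compound 4 (1.48 log units; beyond the scatter), a large step beyond the usual scatter. The two compounds differ in this one place only, so the stronger inhibition goes with this swap, and here the smaller of the two groups is the better one. Nothing shown explains why such a small edit has so large an effect.

Going by these compounds, with only methyl and isopropyl on this carbon, it remains open whether a plain hydrogen, an ethyl group or a cyclopropyl group would give a lower or a higher number. The steps from compound 4 to compound 1 and compound 2, which carry the same methyl, cannot be read.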